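Bromo on the Pyranone Ring of Compound 3

The source may report more compounds than this note shows. Statements on the series, on what has been measured and on what is new or still open speak of the compounds shown alone.

Of the compounds shown here, three with a shared core have been tested in a functional assay on MCF7 cells (Homo sapiens) for inhibition, read by sulforhodamine B assay, with a stated time of 48 h; a lower number here means a stronger inhibitor of growth, a higher number a weaker inhibitor of growth. Compound 1 `COc1ccc(/C=C/C2CC(=O)C=CO2)cc1` gives 156 uM, compound 2 `COc1cc(/C=C/C2CC(=O)C=CO2)cc(OC)c1OC` gives 149 uM, and compound 3 `COc1ccc(C2CC(=O)C=CO2)cc1` gives 173 uM. Compound 3 thus stands with the other two: the gaps between its number and those of compound 1 and compound 2 lie within the usual scatter, so no order among the three can be read from them. Compound 4 `COc1ccc(C2CC(=O)C(Br)=CO2)cc1` differs from compound 3 by bromo in place of hydrogen on a double-bonded ring carbon. For the measured compounds named here, no measured pair shows such a change, so the size of the step is open. Compound 4 is expected to stay close to compound 3, with the step of a 1.4-fold lower number from compound 3 to compound 4 (0.16 log units; within the scatter) estimated at no more than a modest shift. The estimate for compound 4 is 120 uM, within 50 uM to 300 uM.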

Compound 4, concentration for growth inhibition (reported as GI): 42.2 uM
Estimate against measurement, compound 4: 2.8-fold (0.45 log units) above, outside the stated range (below it).
By their numbers in this assay, from the lowest: compound 4; then compounds 2, 1 and 3 (each within the scatter of the next).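

In this assay, for the compounds shown here, bromo in place of hydrogen on a double-bonded ring carbon gives a 4.1-fold lower number from compound 3 to compound 4 (0.61 log units; beyond the scatter), the only step in this set that lies beyond the scatter. This shows that the position two ring bonds from the ring oxygen responds to a change, which compound 1, compound 2 and compound 3, all carrying hydrogen there, could not show. Nothing given here accounts for the lower number.

On these data alone, whether the step is particular to bromo stays open, as no chloro, methyl or amine group stands at this carbon. Also open, as far as these compounds go, is whether bromo would give a similar step on the core of compound 1 or compound 2.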